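Pyrazole carboxylic acid series: BJAB antiproliferation notes

The compounds below may be only part of what the source reports. "The series", "measured", "known", "first", "only" and "open" are said of these compounds alone.

Measured so far:
- compound 1 `Cc1cc(Cl)cc(-c2c(C)nn(-c3nc(-c4ccc(Cl)c(Cl)c4)c(SC(C)C)s3)c2C(=O)O)c1`: 663 nM
- compound 2 `Cc1c(-c2cc(Cl)cc(Cl)c2)c(C(=O)O)nn1-c1nc(-c2ccncc2)c(SC(C)C)s1`: "not active" (no number reported)
- compound 3 `COC(=O)c1c(Cc2ccccc2[N+](=O)[O-])c(C)nn1-c1nc(-c2ccc(Cl)c(Cl)c2)c(SC(C)C)s1`: 93000 nM

The read-out is a functional assay on BJAB cells (Homo sapiens) for antiproliferative activity, with a stated time of 4 days; a lower number here means that less compound is needed, a higher number that more compound is needed for the effect. Compound 1 has the lowest of the two numbers available; compound 3 sits far higher, and the gap between them lies beyond the scatter. Compound 2 gave no number at all, only a statement of inactivity, so it cannot be placed against the others. Going by the values given here, no two measured compounds differ in a single place, so no measured step exists yet.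

The next compound, compound 4 `COc1ccc(C)cc1-c1c(C)nn(-c2nc(-c3ccc(Cl)c(Cl)c3)c(SC(C)C)s2)c1C(=O)O`, keeps the shared core of compound 1 and changes only the aryl group on the pyrazole: 2-methoxy-5-methylphenyl in place of 3-chloro-5-methylphenyl on an aromatic carbon. A chlorine leaves and a hydrogen-bond acceptor enters; the ring count and charge stay the same.

Nothing measured here speaks to an exchange of this kind, so the expectation rests on compound 1 alone. The step from compound 1 to compound 4 is expected to be small and toward a higher number, a 2.3-fold higher number from compound 1 to compound 4 (0.35 log units; beyond the scatter), at the edge of the scatter. Compound 4 is therefore estimated at 1500 nM, within 400 nM to 6000 nM.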

Compound 4, half-maximal effective concentration: 9500 nM
Estimate against measurement, compound 4: 6.3-fold (0.80 log units) below, outside the stated range (above it).
By their numbers in this assay, from the lowest: compound 1; then compound 4; then compound 3.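

In this assay, going by these compounds alone, replacing 3-chloro-5-methylphenyl with 2-methoxy-5-methylphenyl gives the first measured step, a 14-fold higher number from compound 1 to compound 4 (1.16 log units; beyond the scatter), so the aryl group on the aromatic carbon next to the ring atom that bears a carboxy group is not interchangeable in this read-out. The methyl group is named at the same place in both aryl groups, but the chlorine and the methoxy group are named at different places, so this single step combines three things: the loss of chlorine, the gain of methoxy and a change of substituent place on the aryl ring. Nothing available explains the size of this step.

The compounds shown leave open how 2-chloro-5-methylphenyl or 3-methoxy-5-methylphenyl would read at this position, and either could help separate the identity of the group from its place on the aryl ring. Also open, as far as these compounds go, is whether a smaller replacement for the chlorine, such as fluorine, or an amine at the same place on the aryl ring would keep the number nearer that of compound 1.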